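The compounds below may be only part of what the source reports. "The series", "measured", "known", "first", "only" and "open" are said of these compounds alone.

Compound 3 `CCN(CC)CC(=O)OC1CC2(N3CCCCC3)CC(c3ccccc3)C1C(c1ccccc1)C2` gives 23900 nM in an ADME assay on L6 cells (Rattus norvegicus) for cytotoxicity, with a stated time of 72 h (on this read-out lower numbers stand for stronger inhibition and higher numbers for weaker inhibition), the highest of the three numbers recorded there. Compound 2 `O=C(CN1CCCCC1)OC1CC2(N3CCCC3)CC(c3ccccc3)C1C(c1ccccc1)C2` gives 14200 nM, which lies within the scatter of compound 3, while compound 1 `O=C(/C=C/c1ccccc1)OC1CC2(N3CCCCC3)CC(c3ccccc3)C1C(c1ccccc1)C2` gives 10500 nM. Among the measured compounds shown here, the one step between compounds differing in a single place, a 2.3-fold higher number from compound 1 to compound 3 (0.36 log units; beyond the scatter), concerns the group on the carbonyl carbon and is modest. Compound 4 `CCN(CC)CC(=O)OC1CC2(N3CCCC3)CC(c3ccccc3)C1C(c1ccccc1)C2` differs from compound 3 by pyrrolidin-1-yl in place of piperidin-1-yl on a saturated ring carbon. For the measured compounds named here, no measured step touches that ring, so nothing among the recorded numbers bears directly on this change. For compound 4 the account therefore expects no shift beyond the scatter, a 1.3-fold lower number from compound 3 to compound 4 (0.10 log units; within the scatter). Compound 4 is estimated at 19000 nM, within a range from 8000 nM to 42000 nM.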

Compound 4, half-maximal inhibitory concentration: 49000 nM
Compound 4: the middle estimate sits 2.6-fold (0.41 log units) below what was measured; measured number above the stated range.
By their numbers in this assay, from the lowest: compounds 1, 2 and 3 (each within the scatter of the next, the first and the last beyond it); then compound 4.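

In this assay, among the compounds shown here, the saturated ring carbon bearing the amine does respond: pyrrolidin-1-yl in place of piperidin-1-yl gives a 2.1-fold higher number from compound 3 to compound 4 (0.31 log units; beyond the scatter), the first reading at this position. With pyrrolidin-1-yl held there, diethylamino in place of piperidin-1-yl on the saturated chain carbon bound to a carbonyl carbon gives a 3.5-fold higher number from compound 2 to compound 4 (0.54 log units; beyond the scatter), so the chain group also counts. Nothing on hand accounts for either step. The compounds shown leave open how a morpholin-4-yl or azepan-1-yl group on that ring carbon would read, and whether a dimethylamino group on the chain carbon would fall with diethylamino or with piperidin-1-yl.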